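Cyclopropyl for Isopropyl on the Amide Carbonyl

The source may hold more compounds than are shown below. What is called first, only, known or untested is meant among the compounds shown, and "the series" means these compounds.

Compound 1 `CCC(=O)Nc1ccc(Nc2cccc(OC)c2)cc1` gives 61 nM in an assay on isolated protein for binding affinity to melatonin receptor type 1A (Homo sapiens); on this read-out lower numbers stand for stronger inhibition and higher numbers for weaker inhibition. Compound 2 `COc1cccc(Nc2ccc(NC(=O)C(C)C)cc2)c1` gives > 500 nM in this assay.

The value of compound 2 is a limit of the assay, not a number (the limit of > 500 nM in this assay, at which 1 of the 2 values shown sits). Compound 3 `COc1cccc(Nc2ccc(NC(=O)C3CC3)cc2)c1` differs from compound 2 by cyclopropyl in place of isopropyl on a carbonyl carbon. Among the compounds with values here, the only measured step, an at least 8.1-fold higher number from compound 1 to compound 2 (0.91 log units; beyond the scatter), concerns a different change at the same carbonyl, so it bears on this step only loosely. With compound 2 already at the limit, compound 3 is expected to remain weak, and a step of an at least 1.2-fold lower number from compound 2 to compound 3 (0.09 log units; that floor lies within the scatter) is estimated. Compound 3 is estimated at 400 nM, within a range from 80 nM to 2000 nM.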

Compound 3, inhibition constant: 61 nM
Compound 3: the middle estimate sits 6.6-fold (0.82 log units) above what was measured; the whole stated range lies above it.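

Swapping isopropyl for cyclopropyl on the carbonyl, with the heavy-atom count unchanged, gives an at least 8.1-fold lower number from compound 2 to compound 3 (0.91 log units; beyond the scatter), so the outcome at this position follows the kind of group and not its size in atoms alone. Compound 2 stands at a limit and not at a number, so this step is only a floor: the limit of > 500 nM in this assay, at which 1 of the 3 values shown sits.

Cyclopropyl and ethyl cannot be told apart on this carbonyl, with no change at the digits printed from compound 1 to compound 3 (within the scatter).

The compounds shown leave open how cyclobutyl or a longer chain such as butyl would read at this carbonyl.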